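The source may hold more compounds than are shown below. What is called first, only, known or untested is meant among the compounds shown, and "the series" means these compounds.

In a functional assay on DU-145 cells (Homo sapiens) for cytotoxicity (on this read-out higher numbers stand for weaker inhibition of growth and lower numbers for stronger inhibition of growth), compound 2 `OCCCCC#Cc1ccccc1C#Cc1ccccc1` gives 5220 nM, the lowest of the three numbers recorded so far. Compound 1 `OCCC#Cc1ccccc1C#Cc1ccccc1` gives 12500 nM, and the step of a 2.4-fold lower number from compound 1 to compound 2 (0.38 log units; beyond the scatter). Compound 3 `OCCCCC#Cc1ccccc1C#Cc1cccs1` gives 13000 nM, and the step of a 2.5-fold higher number from compound 2 to compound 3 (0.40 log units; beyond the scatter). Compound 4 `OCCCCC#Cc1ccccc1C#Cc1ccccc1C(F)(F)F` differs from compound 2 by trifluoromethyl in place of hydrogen on an aromatic carbon. Going by the values given here, no measured step adds a group to this ring; the only change touching it, the swap of that ring in going from compound 2 to compound 3, was modest and offers limited guidance. For compound 4 the expected step is a 1.1-fold higher number from compound 2 to compound 4 (0.02 log units; within the scatter), within the scatter. The estimate for compound 4 is 5500 nM, with a range from 2200 nM to 14000 nM.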

Compound 4, concentration for 50% growth inhibition: 6100 nM
For compound 4 the middle estimate is 1.1-fold (0.04 log units) below the measured one; the measured number falls inside the stated range.
By their numbers in this assay, from the lowest: compounds 2 and 4 (each within the scatter of the next); then compounds 1 and 3 (each within the scatter of the next).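

Trifluoromethyl in place of hydrogen on an aromatic carbon, ortho to a large group, gives in this assay a 1.2-fold higher number from compound 2 to compound 4 (0.07 log units; within the scatter) and so no change that can be told from the scatter. The earlier compounds shown here showed only the swap of this whole ring, whereas here the ring stays and this position takes on an added group with no clear effect on growth inhibition. No measurement at hand explains this result.

From the compounds shown here alone, whether an amine, a methoxy group or a carboxylic acid on the same carbon would behave alike remains open. So does whether trifluoromethyl on another carbon of this ring would give a different number.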